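Trifluoromethyl for Methyl on a Sulfonyl Aryl Ring

A few compounds are considered here, and "the series" means these few. Any claim that something is new, unique, unknown or untested is made for them only; others in the source may bear on it.

Compound 1 `Cc1cc(F)ccc1S(=O)(=O)N1CCN(c2ccc(C(=O)NCc3ccc(F)cc3)nn2)CC1`: 0.25 h
Compound 2 `N#Cc1ncccc1S(=O)(=O)N1CCN(c2ccc(C(=O)NCc3ccc(F)cc3)[n+]([O-])n2)CC1`: 0.267 h

In an ADME assay on microsomes from liver (Mus musculus) for metabolic stability, read by LC-MS, using NADPH, tested at 10 uM (on this read-out lower numbers stand for a shorter-lived compound and higher numbers for a longer-lived compound), compound 1 gives 0.25 h, and compound 2 gives 0.267 h. These two numbers lie within the usual scatter of each other, so compound 1 stands level with compound 2 rather than apart from it. Compound 3 `O=C(NCc1ccc(F)cc1)c1ccc(N2CCN(S(=O)(=O)c3ccc(F)cc3C(F)(F)F)CC2)nn1` differs from compound 1 in one place: trifluoromethyl in place of methyl on an aromatic carbon. Among the measured compounds shown here, no measured pair shows this change, so nothing among the measured compounds fixes its size. A small step toward a longer half-life is expected, a 1.6-fold higher number from compound 1 to compound 3 (0.20 log units; within the scatter). Compound 3 is therefore estimated at 0.4 h, with a range of 0.2 h to 0.9 h.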

Compound 3, half-life: 0.2 h
Compound 3: middle estimate off by 2.0-fold (0.30 log units), on the high side, and the stated range covers the measured number.
By their numbers in this assay, from the lowest: compounds 3, 1 and 2 (each within the scatter of the next).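

Putting trifluoromethyl in place of methyl on this aromatic carbon, ortho to a large group, gives a 1.3-fold lower number from compound 1 to compound 3 (0.10 log units; within the scatter) in this assay. The half-life therefore stays level across this change, so the larger group does not lengthen it here. Nothing measured offers a reason for this.

Still open, on these data alone, is whether a different group at this place, such as an amine, a carboxylic acid or a longer chain, would shift the half-life beyond the scatter. As far as these compounds go, whether the same change behaves alike on another core is also open.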